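A Cyclopropyl Group on an Amide Nitrogen

This account rests on a few compounds, and the source may have more. Where it says the series, first, only, none or still open, it means among the compounds named here.

In a functional assay on HCT-116 cells (Homo sapiens) for inhibition, read by MTT assay, with a stated time of 72 h (on this read-out lower numbers stand for stronger inhibition of growth and higher numbers for weaker inhibition of growth), compound 1 `CC(C)[C@@H](NC(=O)/C=C/c1ccncc1-c1ccc2ccccc2c1)C(=O)O` gives "not determined" (no result reported). Among the measured compounds shown here, that leaves compound 2 `NC(=O)/C=C/c1ccncc1-c1ccc2ccccc2c1`, at 12100 nM, with the only number available, so it cannot yet be ranked against anything. Compound 3 `O=C(/C=C/c1ccncc1-c1ccc2ccccc2c1)NC1CC1` differs from compound 2 in one place: cyclopropyl in place of hydrogen on an amide-type nitrogen, with cyclopropyl in place of hydrogen on an amide-type nitrogen. For the measured compounds named here, no measured step is available as a guide, so this is a cautious expectation. The expected change is a 2.0-fold lower number from compound 2 to compound 3 (0.30 log units; within the scatter), a modest move towards stronger growth inhibition. For compound 3 the estimated value is 6000 nM, with an expected range of 1500 nM to 25000 nM.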

Compound 3, concentration for 50% growth inhibition: 6180 nM
For compound 3 the middle estimate is 1.0-fold (0.01 log units) below the measured one, and the stated range covers the measured number.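

Among the compounds shown here, with cyclopropyl in place of hydrogen on the amide-type nitrogen, this assay gives a 2.0-fold lower number from compound 2 to compound 3 (0.29 log units; within the scatter), the first measured step at this position. So this nitrogen can carry cyclopropyl without a shift beyond the usual scatter, and the two compounds cannot be ranked. Nothing measured here explains this result. From the compounds shown here alone, whether a larger group on this nitrogen, such as a cyclohexyl ring or a longer chain ending in an amine, would move the number beyond the scatter remains open. Compound 1 has no reported result, so it cannot help settle this.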